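Replacing a methoxy pyridazine with a methyl pyridazine

The source may hold more compounds than are shown below. What is called first, only, known or untested is meant among the compounds shown, and "the series" means these compounds.

Measured so far:
Compound 1 `Cc1ccc(N2CCN(C(=O)Nc3ccc(C(C)C)cc3)CC2)nn1`: > 10000 nM in an assay on HEK293 cells for inhibition of transient receptor potential cation channel subfamily V member 1 (Homo sapiens), read by FLIPR, at pH 5.5 (on this read-out higher numbers stand for weaker inhibition and lower numbers for stronger inhibition), which is a limit of the assay and not a number.
Compound 2 `Cc1ccc(N2CCN(C(=O)Nc3ccc(C(F)(F)F)cc3)CC2)nn1`: > 10000 nM in this assay, again a limit.
Compound 3 `COc1ccc(N2CCN(C(=O)Nc3nc4ccc(F)cc4s3)CC2)nn1`: > 10000 nM in this assay, again a limit.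

Compound 3 therefore stands where every measured compound stands: at the limit of > 10000 nM in this assay, at which 3 of the 3 values shown sit. Going by the values given here, no compound here has given a number inside the range of the assay.

Compound 4 `Cc1cnnc(N2CCN(C(=O)Nc3nc4ccc(F)cc4s3)CC2)c1` differs from compound 3 in one place: 5-methylpyridazin-3-yl in place of 6-methoxypyridazin-3-yl on an amine nitrogen in a ring. Among the compounds with values here, the only measured step between single-change neighbours is a step that the two limits leave unreadable from compound 1 to compound 2, and it concerns the anilide end, not the pyridazine carried on the ring nitrogen. It gives no readable size and no direction.

Within the data shown here, with every value at the limit, and the one measured step unreadable, nothing supports an expectation that compound 4 moves into the measurable range. Compound 4 is therefore expected to give about 15000 nM in this assay, within 5000 nM to 50000 nM, most likely reported as a limit again. The expected step is a step that the limit leaves unreadable from compound 3 to compound 4, that is, none that can be read.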

Compound 4, half-maximal inhibitory concentration: > 10000 nM
Compound 4: no number, only a limit; the forecaster's own chance of this, stated with the estimate: 75%; the middle value does not contradict the limit.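

The step from compound 3 to compound 4 cannot be read, since both compounds give only a limit and not a number: the limit of > 10000 nM in this assay, at which 4 of the 4 values shown sit. The compounds shown leave open whether any change to the shared core brings a value inside the range of the assay.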